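This account rests on a few compounds, and the source may have more. Where it says the series, first, only, none or still open, it means among the compounds named here.

The measured compounds and their numbers in an assay on cells for displacement of a labelled ligand from Glucagon receptor (Homo sapiens), in the presence of a further agent that is not named here; on this read-out higher numbers stand for weaker inhibition and lower numbers for stronger inhibition:

Compound 1 `O=C(O)CCNC(=O)c1ccc(C(Oc2ccc(-n3cc(C(F)(F)F)cn3)cc2)C2CCC2)cc1` gives 700 nM.
Compound 2 `CCC(Oc1ccc(-n2cc(C(F)(F)F)cn2)cc1)c1ccc(C(=O)NCCC(=O)O)cc1` gives 1400 nM.
Compound 3 `CCCC(Oc1ccc(-n2cc(Cl)cn2)cc1)c1ccc(C(=O)NCCC(=O)O)cc1` gives 1100 nM.

Compound 1 has the lowest number of the three in this assay, but its gaps to compound 3 and to compound 2 are both within the scatter, so no ordering among them can be claimed. Compound 4 `CCCC(Oc1ccc(-n2cc(C(F)(F)F)cn2)cc1)c1ccc(C(=O)NCCC(=O)O)cc1` has not yet been measured. It differs from compound 1 in one place: propyl in place of cyclobutyl on a saturated chain carbon bound to an aromatic carbon and an oxygen on an aromatic ring.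

For the measured compounds named here, the one measured step at this position is a 2.0-fold higher number from compound 1 to compound 2 (0.30 log units; within the scatter), which stays within the scatter. Going by the values given here, compound 3 already carries a propyl at the same position and sits close to compound 1 in this assay, though it differs from compound 4 elsewhere, so no step between them is given here. Taken together, the trading of the cyclobutyl for an open chain at this position has so far produced no change beyond the scatter in this assay, and the same is expected for compound 4, that is, a step of a 1.4-fold higher number from compound 1 to compound 4 (0.15 log units; within the scatter) that stays within the scatter. Compound 4 is therefore estimated at 1000 nM, with a range from 500 nM to 2200 nM.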

Compound 4, inhibition constant: 890 nM
The estimate for compound 4 lay 1.1-fold (0.05 log units) above the measured number; the measured number falls inside the stated range.
By their numbers in this assay, from the lowest: compounds 1, 4, 3 and 2 (each within the scatter of the next).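

In this assay, for the compounds shown here, the step of a 1.3-fold higher number from compound 1 to compound 4 (0.10 log units; within the scatter) is the first reading of propyl against cyclobutyl with the rest of the structure held fixed, and it gives no sign that the four-membered ring matters at this position. The step of a 1.6-fold lower number from compound 2 to compound 4 (0.20 log units; within the scatter) leaves ethyl and propyl unresolved as well, so the open chains shown cannot be told apart from each other or from the cyclobutyl. The step of a 1.2-fold lower number from compound 3 to compound 4 (0.09 log units; within the scatter) adds a second place, where trifluoromethyl and chloro on an aromatic carbon likewise cannot be told apart.

From the compounds shown here alone, whether an amine, a hydroxyl or a much longer chain on this saturated chain carbon would move the number beyond the scatter stays open. Nothing available here bears on why these compounds read so alike.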